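The compounds below may be only part of what the source reports. "The series", "measured", "known", "first", "only" and "open" are said of these compounds alone.

Series notes, aminotriazine scaffold bearing a methylpiperazine and an aryloxymethyl arm.

Compound 1 `CN1CCN(c2nc(N)nc(COc3cccc(Cl)c3)n2)CC1` is the reference point. Among the measured compounds shown here, in an assay on HEK293 cells for displacement of a labelled ligand from 5-hydroxytryptamine receptor 7 (Homo sapiens), read by radioligand binding, with a stated time of 1 h (on this read-out lower numbers stand for stronger inhibition and higher numbers for weaker inhibition), compound 1 gives 5820 nM, the lower of the two numbers so far. For the measured compounds named here, the only comparator is compound 2 `Cc1ccc(OCc2nc(N)nc(N3CCN(C)CC3)n2)cc1`, which in this assay gives 16100 nM; the single change of 4-methylphenyl in place of 3-chlorophenyl on an oxygen on a saturated carbon costs a 2.8-fold higher number from compound 1 to compound 2 (0.44 log units; beyond the scatter).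

Compound 3 `CC(Oc1cccc(Cl)c1)c1nc(N)nc(N2CCN(C)CC2)n1` is not yet measured. Relative to compound 1 the change is methyl in place of hydrogen on a saturated chain carbon bound to an aromatic carbon and an oxygen on an aromatic ring. Going by the values given here, no measured step touches this position: the one step in hand, a 2.8-fold higher number from compound 1 to compound 2 (0.44 log units; beyond the scatter), concerns the aryl ring on the oxygen and leaves the saturated chain carbon untouched, so it gives no direction for the methyl. With the 3-chlorophenyl retained, the expectation is a step from compound 1 to compound 3 of no more than the scatter, written as a 1.0-fold lower number from compound 1 to compound 3 (0.00 log units; within the scatter). Compound 3 is therefore estimated at 5800 nM, with a range from 2200 nM to 15000 nM, the width reflecting the absence of any precedent for this change.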

Compound 3, inhibition constant: 8360 nM
Beside the measured number, compound 3's estimate is 1.4-fold (0.16 log units) below it, within the range that was stated.
By their numbers in this assay, from the lowest: compounds 1, 3 and 2 (each within the scatter of the next, the first and the last beyond it).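

In this assay, the saturated chain carbon bound to an aromatic carbon and an oxygen on an aromatic ring now has a measured step of its own (a 1.4-fold higher number from compound 1 to compound 3 (0.16 log units; within the scatter)), so methyl in place of hydrogen at this position gives no change that can be told from the scatter. Among the compounds shown here, with the 3-chlorophenyl retained, this carbon therefore tolerates the added methyl in this read-out, whereas the only earlier step concerned the aryl ring on the oxygen and showed nothing about this position. No available measurement offers an explanation for this result.

The compounds shown carry only hydrogen or a single methyl on this carbon, so it remains open whether an ethyl group, a longer chain, a hydroxyl group or an amine in the same place would also stay within the scatter. For the compounds shown here, the methyl is also seen only with the 3-chlorophenyl, which leaves open whether it would give a similarly small step when paired with the 4-methylphenyl of compound 2.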